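From amino to ureido on compound 3

The compounds below may be only part of what the source reports. "The series", "measured", "known", "first", "only" and "open" are said of these compounds alone.

Measured so far in an ADME assay on microsomes from liver (Homo sapiens) for metabolic stability, using NADPH, with a stated time of 10 min; on this read-out higher numbers stand for a more stable compound and lower numbers for a less stable compound:
compound 1 `NCCCCN(C[C@@H]1Cc2nccnc2CN1)[C@H]1CCCc2cccnc21`: 87%
compound 2 `CN(C[C@@H]1Cc2ncccc2CN1)[C@H]1CCCc2cccnc21`: 100%
compound 3 `NC/C=C\CN(C[C@H]1Cc2ncccc2CN1)[C@H]1CCCc2cccnc21`: 85%

Compound 3 at 85% lies within the scatter of compound 1 at 87%. Compound 2 at 100% reads higher than compound 3, and that gap is beyond the scatter. All three values sit near the top of the scale, so little room remains for any upward movement.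

The next compound is compound 4 `NC(=O)NC/C=C\CN(C[C@H]1Cc2ncccc2CN1)[C@H]1CCCc2cccnc21`, which has carbamoyl in place of hydrogen on an amine nitrogen. This turns amino to ureido, and aminomethyl to ureidomethyl. For the measured compounds named here, no two measured compounds differ in one place only, so the series offers no direct precedent for this change in this assay. Compound 2 at 100% has no terminal amino group, which gives weak support for a flat or slightly upward move. No step beyond the scatter is expected, and the estimated change is a number 3 percentage points higher from compound 3 to compound 4 (within the scatter). For compound 4 the estimated value is 88%, with an expected range of 77% to 100%.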

Compound 4, percent of the compound remaining: 100%
For compound 4 the middle estimate is 12 percentage points below the measured one, within the range that was stated.
By their numbers in this assay, from the lowest: compounds 3 and 1 (each within the scatter of the next); then compounds 2 and 4 (each within the scatter of the next).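

In this assay, for the compounds shown here, carbamoyl in place of hydrogen on an amine nitrogen gives the first step between two compounds that differ in one place only, a number 15 percentage points higher from compound 3 to compound 4 (beyond the scatter). The amine nitrogen at the end of the chain of compound 3 therefore accepts this substitution without any loss on this read-out, and the change from amino to ureido carries compound 4 to 100%, the top of the scale. The data at hand hold nothing that accounts for the size of this step.

The compounds shown leave open whether the step belongs to the carbamoyl group itself or would also appear with an acetyl or a methylsulfonyl group on the same nitrogen. Also open, on these data alone, is whether the same change would hold on the saturated chain and the core of compound 1, and with compound 4 at the top of the scale, any further rise from a new group could not be seen in this assay.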